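Taking the methyl off the nitrogen of compound 2

The source may hold more compounds than are shown below. What is called first, only, known or untested is meant among the compounds shown, and "the series" means these compounds.

In a functional assay on MDA-MB-435 cells (Homo sapiens) for inhibition, read by sulforhodamine B assay, with a stated time of 48 h (on this read-out lower numbers stand for stronger inhibition and higher numbers for weaker inhibition), compound 1 `COc1ccc(N(C)c2nc(N)nc3c2CCC3)cc1` gives 16.7 nM and compound 2 `COc1ccc(N(C)c2nc(N)nc3c2CC(C)C3)cc1` gives 29.9 nM. That is a 1.8-fold higher number from compound 1 to compound 2 (0.25 log units; within the scatter), so compound 2 stands level with compound 1, and the two cannot be told apart.

Compound 3 `COc1ccc(Nc2nc(N)nc3c2CC(C)C3)cc1` differs from compound 2 in one place: hydrogen in place of methyl on a nitrogen on an aromatic ring. Within the data shown here, the single measured step concerns a saturated ring carbon, not this nitrogen, so it offers no direct guide to the size of this change. Among the measured compounds shown here, nothing measured so far shows what this methyl contributes.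

The expectation is therefore tentative: a weaker result, with a higher number in this assay, and an estimated step of a 6.7-fold higher number from compound 2 to compound 3 (0.83 log units; beyond the scatter). Compound 3 is estimated at 200 nM, with an expected range from 30 nM to 2000 nM.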

Compound 3, half-maximal inhibitory concentration: > 10000 nM
Compound 3: no number, only a limit; the forecaster's own chance of this, stated with the estimate: 10%; middle value at least 50-fold (1.69 log units) away from the limit.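

In this assay compound 3 gives no true number, only a limit of the assay, > 10000 nM, and that limit marks where the reading stops: the limit of > 10000 nM in this assay, at which 1 of the 3 values shown sits.

Even so, swapping the methyl on this nitrogen for hydrogen gives an at least 330-fold higher number from compound 2 to compound 3 (2.52 log units; beyond the scatter), so the loss of one carbon atom here takes inhibition out of the range this assay can read. Among these compounds, the earlier change on the saturated ring carbon stayed within the scatter, which makes this nitrogen, among the places compared so far, the one where a small change matters most.

The compounds shown cannot tell whether the methyl is uniquely suited to this nitrogen, or whether an ethyl group or a longer chain would serve as well. They also leave open whether hydrogen on this nitrogen costs as much on the core of compound 1, which lacks the ring methyl.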